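A few compounds are considered here, and "the series" means these few. Any claim that something is new, unique, unknown or untested is made for them only; others in the source may bear on it.

Measured so far in a functional assay, read by fluorescence and spectrophotometry, with a stated time of 1 h; on this read-out higher numbers stand for an effect only at larger amounts of compound and lower numbers for an effect already at smaller amounts:
compound 1 `O=S(=O)(/C=C/c1ccc(O)c(O)c1)CC1CCC1` 8800 nM
compound 2 `O=S(=O)(/C=C/c1ccc(O)c(O)c1)CC1CCCO1` 10500 nM

Compound 2 and compound 1 lie within the scatter of each other on this assay; the one step shown, a 1.2-fold higher number from compound 1 to compound 2 (0.08 log units; within the scatter), exchanged one ring for another on the saturated chain carbon bound to a sulfonyl sulfur without a change beyond the scatter.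

Compound 3 `O=S(=O)(/C=C/c1ccc(O)c(O)c1)CC1CCCN1` is not yet measured. Its change from compound 2: pyrrolidin-2-yl in place of oxolan-2-yl on a saturated chain carbon bound to a sulfonyl sulfur

Going by the values given here, the single measured step that touches the same place, a 1.2-fold higher number from compound 1 to compound 2 (0.08 log units; within the scatter), bears on this change only loosely, since the ring it exchanged carries no hydrogen-bond donor. Among the compounds with values here, no measured pair shows what a hydrogen-bond donor at this position does. Within the data shown here, with the one step at this place within the scatter, the working expectation for compound 3 is a step of about a 1.1-fold lower number from compound 2 to compound 3 (0.02 log units; within the scatter), that is no change beyond the scatter, with a wide range to cover the untested donor. Compound 3 is therefore estimated at 10000 nM in this assay, in the range 3500 nM to 28000 nM.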

Compound 3, half-maximal effective concentration: 13800 nM
Estimate against measurement, compound 3: 1.4-fold (0.14 log units) below, within the range that was stated.
By their numbers in this assay, from the lowest: compounds 1, 2 and 3 (each within the scatter of the next).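

In this assay, pyrrolidin-2-yl on a saturated chain carbon bound to a sulfonyl sulfur gives a 1.3-fold higher number from compound 2 to compound 3 (0.12 log units; within the scatter) with oxolan-2-yl leaving, and a 1.6-fold higher number from compound 1 to compound 3 (0.20 log units; within the scatter) with cyclobutyl leaving. A ring carrying a hydrogen-bond donor at this place therefore shows no change beyond the scatter against either ring without one, and the three rings cannot be ordered on this read-out. No supporting data on these compounds offer a reason for this result.

Still open, on these data alone, is whether a carboxylic acid, an open-chain amine or a longer alkyl chain at this place would move the number beyond the scatter. Also open, as far as these compounds go, is whether an aromatic ring such as phenyl would leave the number within the scatter of these three saturated and non-aromatic rings.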